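Three Close Values and One Unmeasured Swap

This account rests on a few compounds, and the source may have more. Where it says the series, first, only, none or still open, it means among the compounds named here.

In a functional assay on MCF7 cells (Homo sapiens) for antiproliferative activity, read by MTT assay, with a stated time of 72 h (a lower number here means a stronger inhibitor, a higher number a weaker inhibitor), compound 1 `CCCSc1nc(N/N=C/c2ccccc2Cl)c2nnn(Cc3ccccc3)c2n1` gives a value (13800 nM) that lies within the usual scatter of those of compound 2 `CCCSc1nc(N/N=C(\C)c2ccccc2O)c2nnn(Cc3ccc(O)cc3)c2n1` (9520 nM) and compound 3 `CCCSc1nc(N/N=C/c2c[nH]c3ccccc23)c2nnn(Cc3ccccc3)c2n1` (9010 nM). On these numbers, compound 1 cannot be told apart from the other two. Compound 4 `CCCSc1nc(N/N=C(\C)c2ccccc2)c2nnn(Cc3ccccc3)c2n1` has not been measured yet. It keeps the shared core of compound 1 and differs as follows: a group of 9 heavy atoms (8 carbon, 1 nitrogen; one six-membered aromatic ring of carbon only) in place of a group of 9 heavy atoms (7 carbon, 1 nitrogen, 1 chlorine; one six-membered aromatic ring of carbon only), on a nitrogen on an aromatic ring and nothing else changes. Within the data shown here, one measured step bears on this, the swap of 2-chlorophenyl for 1H-indol-3-yl (a 1.5-fold lower number from compound 1 to compound 3 (0.19 log units; within the scatter)), and it stayed within the scatter. One step is thin evidence, but the expected change (a 1.3-fold lower number from compound 1 to compound 4 (0.10 log units; within the scatter)) is likewise none beyond the scatter. Compound 4 is expected at 11000 nM with an estimated range (5000 nM to 24000 nM).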

Compound 4, half-maximal inhibitory concentration: 32100 nM
Beside the measured number, compound 4's estimate is 2.9-fold (0.47 log units) below it; the measured number lies above the stated range.
By their numbers in this assay, from the lowest: compounds 3, 2 and 1 (each within the scatter of the next); then compound 4.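

Among these compounds, the change shows a 2.3-fold higher number from compound 1 to compound 4 (0.37 log units; beyond the scatter), the first single-place step here to pass beyond the scatter. The group on this nitrogen can therefore shift the result, even when a chlorine-bearing group gives way to a chlorine-free one of the same heavy-atom count, whereas the earlier swap to 1H-indol-3-yl did not show this. Nothing measured here explains the step. Going by these compounds, whether losing the chlorine or gaining the extra carbon matters more stays open. So does how a group carrying an amine or a carboxylic acid would behave in this place.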